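The source may report more compounds than this note shows. Statements on the series, on what has been measured and on what is new or still open speak of the compounds shown alone.

Measured so far in a functional assay on T47D cells (Homo sapiens) for cytotoxicity, read by MTT assay, with a stated time of 2 days; on this read-out lower numbers stand for stronger inhibition and higher numbers for weaker inhibition:
- compound 1 `Cc1ccc2nc(-c3ccccc3C(F)(F)F)[nH]c(=O)c2c1` gives > 50000 nM, which is a limit of the assay, not a number.
- compound 2 `CCN(CC)c1ccc2nc(-c3ccccc3N(C)C)[nH]c(=O)c2c1` gives 2210 nM.
- compound 3 `Cc1ccc2nc(-c3ccccc3N(C)C)[nH]c(=O)c2c1` gives 26700 nM.

Compound 3 stands highest of the two numbers given; the nearest, compound 2, lies lower by a 12-fold higher number from compound 2 to compound 3 (1.08 log units; beyond the scatter), a step beyond the scatter. Compound 1 sits at a limit (the limit of > 50000 nM in this assay, at which 1 of the 3 values shown sits). The step from compound 1 to compound 3, an at least 1.8-fold lower number from compound 1 to compound 3 (0.27 log units; that floor lies within the scatter), is only a floor and lies within the scatter.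

Compound 4 `Cc1ccc2nc(-c3ccccc3OC(F)(F)F)[nH]c(=O)c2c1` differs from compound 3 in one place: trifluoromethoxy in place of dimethylamino on an aromatic carbon. Going by the values given here, two measured steps bear on this. The step of a 12-fold higher number from compound 2 to compound 3 (1.08 log units; beyond the scatter) shows that a change at the other position moves the number strongly, while an at least 1.8-fold lower number from compound 1 to compound 3 (0.27 log units; that floor lies within the scatter) shows that replacing trifluoromethyl by dimethylamino on this aromatic carbon lowered the number by at least a small margin from a limit. Trifluoromethoxy resembles trifluoromethyl more than dimethylamino, so the number is expected to rise again, plausibly back toward a limit. Compound 4 is therefore estimated at 45000 nM in this assay, within 15000 nM to 120000 nM, an expected step of a 1.7-fold higher number from compound 3 to compound 4 (0.23 log units; within the scatter).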

Compound 4, half-maximal inhibitory concentration: > 50000 nM
Compound 4: only a limit was reported (the forecaster's own chance of this, stated with the estimate: 45%); middle value at least 1.1-fold (0.04 log units) away from the limit.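

In this assay, as far as these compounds go, trifluoromethoxy in place of dimethylamino on this aromatic carbon gives an at least 1.8-fold higher number from compound 3 to compound 4 (0.27 log units; that floor lies within the scatter), so the true size of this change remains unknown. Compound 4 gives > 50000 nM, which is a limit of the assay and not a number, and the step between compound 1 and compound 4 cannot be read. Among the compounds shown, only those with dimethylamino at this place, compound 2 and compound 3, give a number rather than a limit: the limit of > 50000 nM in this assay, at which 2 of the 4 values shown sit.

From the compounds shown here alone, it remains open whether another group at this place, such as a primary amine, methoxy or a carboxylic acid, would give a number in this assay. Also open, going by these compounds, is whether diethylamino in place of the methyl group, the change that separates compound 3 from compound 2, would give a number with trifluoromethoxy present.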